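The source may report more compounds than this note shows. Statements on the series, on what has been measured and on what is new or still open speak of the compounds shown alone.

Compound 1, `Cc1cn([C@@H]2O[C@H](CO[Si](C)(C)C(C)(C)C)[C@@]3(OS(=O)(=O)C=C3NCC(=O)O)[C@H]2O[Si](C)(C)C(C)(C)C)c(=O)n(C)c1=O`: 300000 nM. Compound 2, `CCOC(=O)NC(=O)NC1=CS(=O)(=O)O[C@@]12[C@@H](CO[Si](C)(C)C(C)(C)C)O[C@@H](n1cc(C)c(=O)n(C)c1=O)[C@@H]2O[Si](C)(C)C(C)(C)C`: 16000 nM. Compound 3, `CC(=O)NC1=CS(=O)(=O)O[C@@]12[C@@H](CO[Si](C)(C)C(C)(C)C)O[C@@H](n1cc(C)c(=O)n(C)c1=O)[C@@H]2O[Si](C)(C)C(C)(C)C`: in this assay compound 3 gives >= 80000 nM, which is a limit of the assay and not a number.

All three values come from a functional assay on HEL cells (Homo sapiens) for cytotoxicity, read by microscopy; a lower number here means that less compound is tolerated, a higher number that more compound is tolerated. Among the two readable numbers, compound 1 stands highest; the closest measured value lies a 19-fold lower number from compound 1 to compound 2 (1.27 log units; beyond the scatter).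

Compound 4, `COC(=O)C(=O)CNC1=CS(=O)(=O)O[C@@]12[C@@H](CO[Si](C)(C)C(C)(C)C)O[C@@H](n1cc(C)c(=O)n(C)c1=O)[C@@H]2O[Si](C)(C)C(C)(C)C`, has not been measured. It differs from compound 1 in one place: methoxycarbonyl in place of hydroxy on a carbonyl carbon.

Two measured steps start from compound 1 and both alter the (carboxymethyl)amino group: a 19-fold lower number from compound 1 to compound 2 (1.27 log units; beyond the scatter) and a step that the limit leaves unreadable from compound 1 to compound 3. Between those two products lies an at least 5.0-fold higher number from compound 2 to compound 3 (0.69 log units; beyond the scatter). The change to compound 4 also does away with the carboxy group, so a lower number than for compound 1 is expected, likely large but shorter than the fall to compound 2. Compound 4 is therefore expected to give 60000 nM in this assay, with a range from 15000 nM to 300000 nM. That estimate means a step of a 5.0-fold lower number from compound 1 to compound 4 (0.70 log units; beyond the scatter).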

Compound 4, minimum cytotoxic concentration: > 400000 nM
Compound 4: a limit, no number (the forecaster's own chance of this, stated with the estimate: 25%); at least 6.6-fold (0.82 log units) between middle value and limit.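

In this assay compound 4 gives > 400000 nM, which is a limit of the assay and not a number. Methoxycarbonyl in place of hydroxy on a carbonyl carbon removes the carboxy group of compound 1 with no fall in the number, the step being an at least 1.3-fold higher number from compound 1 to compound 4 (0.12 log units; that floor lies within the scatter), so a free carboxy group is not needed for compound 1's tolerance, though no rise can be claimed. The ((methoxycarbonyl)carbonyl)methyl group also stands clearly apart from the (ethoxycarbonyl)carbamoyl group, with an at least 25-fold higher number from compound 2 to compound 4 (1.39 log units; beyond the scatter), while the step between compound 3 and compound 4 cannot be read.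

On these data alone, how far the number of compound 4 truly lies from that of compound 1 stays open: the limit of > 400000 nM in this assay, at which 1 of the 4 values shown sits. Whether an amide, an amine or a longer chain on this carbonyl carbon would behave like methoxycarbonyl also stays open.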